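This account rests on a few compounds, and the source may have more. Where it says the series, first, only, none or still open, it means among the compounds named here.

In an ADME assay on Huh-7 cells (Homo sapiens) for cytotoxicity, read by MTT assay (a lower number here means that less compound is tolerated, a higher number that more compound is tolerated), compound 1 (`O=c1nc[nH]c2ccc(Oc3ncccc3C(F)(F)F)cc12`) gives > 10 uM, which is a limit and not a number. Compound 2 (`O=c1ncn(CC2CCCCC2)c2ccc(Oc3ncccc3C(F)(F)F)cc12`) gives > 10 uM, which is also a limit. Going by the values given here, the only measured step is a step that the two limits leave unreadable from compound 1 to compound 2, and the evidence on it is the limit of > 10 uM in this assay, at which 2 of the 2 values shown sit. Compound 3 (`O=c1ncn(Cc2ccccc2)c2ccc(Oc3ncccc3C(F)(F)F)cc12`) has not yet been measured, and its change from compound 1 is benzyl in place of hydrogen on an aromatic nitrogen. Compound 2 is the closest measured case, with cyclohexylmethyl in place of that hydrogen, but its step from compound 1 has no readable size. No step beyond the scatter is therefore expected in this assay, and no direction can be given, although compound 3 may well be reported as a limit too. The expected change is a step that the limit leaves unreadable from compound 1 to compound 3. For compound 3 the estimated value is 15 uM, with an expected range from 7 uM to 40 uM.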

Compound 3, half-maximal toxic concentration: > 10 uM
Compound 3 gave a limit, no number (the forecaster's own chance of this, stated with the estimate: 75%); the middle value lies beyond the limit too.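

Going by these compounds alone, compound 3 gives only a limit, as do compound 1 and compound 2, so no step among the three can be read: the limit of > 10 uM in this assay, at which 3 of the 3 values shown sit. The compounds shown leave open whether benzyl or cyclohexylmethyl in place of the hydrogen changes the result in this assay at all.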